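Moving the Chlorine on an Aryl Urea Cytotoxicity Series

A few compounds are considered here, and "the series" means these few. Any claim that something is new, unique, unknown or untested is made for them only; others in the source may bear on it.

The account starts from two measured ureas, compound 1 `O=C(Nc1ccccc1C(=O)O)N[C@H]1CC[C@@H](Oc2ccc(F)cc2)CC1` and compound 2 `O=C(Nc1ccc(Cl)cc1)N[C@H]1CC[C@H](Oc2ccc(F)cc2)CC1`, both examined in a functional assay on CRL2813 cells (Homo sapiens) for cytotoxicity, read by sulforhodamine B assay, with a stated time of 5 days; a lower number here means a stronger inhibitor, a higher number a weaker inhibitor. Compound 1 reaches only the limit of the assay, > 20000 nM. Compound 2 likewise returns only a limit, > 20000 nM. Both readings thus sit at the same limit (the limit of > 20000 nM in this assay, at which 2 of the 2 values shown sit), and nothing separates them on the numbers shown. Compound 3 `O=C(Nc1cccc(Cl)c1)N[C@H]1CC[C@H](Oc2ccc(F)cc2)CC1` differs from compound 2 by a single rearrangement, (3-chlorophenyl in place of 4-chlorophenyl on an amide-type nitrogen). For the measured compounds named here, no step between measured compounds is available to judge the effect of that change, so the expectation rests on compound 2 alone: compound 2 sits at the limit > 20000 nM, and the step that the limit leaves unreadable from compound 2 to compound 3 is expected to be none beyond the scatter of this assay. Compound 3 is therefore estimated at 25000 nM, within a range from 8000 nM to 80000 nM, most likely reported again as a limit.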

Compound 3, half-maximal inhibitory concentration: 5900 nM
Compound 3: the middle estimate sits 4.2-fold (0.63 log units) above what was measured; measured number below the stated range.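

Moving the chlorine from 4-chlorophenyl to 3-chlorophenyl on the amide-type nitrogen gives the first reading in this series that is a number and not a limit: in this assay the change gives an at least 3.3-fold lower number from compound 2 to compound 3 (0.53 log units; beyond the scatter). This shows that the readout at this aryl group depends on where the chlorine stands, which the two earlier compounds, both sitting at the limit, could not show. The full size of the step stays unknown because compound 2 has no number of its own: the limit of > 20000 nM in this assay, at which 2 of the 3 values shown sit.

The compounds shown leave open whether a bromine or a methyl group in place of the chlorine of the 3-chlorophenyl would keep this activity, and how a plain phenyl on the same nitrogen would read. They also do not tell how compound 3 would change with a second chlorine on that ring.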